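A Methoxy Change on a Compound Reported Only as a Limit

This account rests on a few compounds, and the source may have more. Where it says the series, first, only, none or still open, it means among the compounds named here.

Compound 1 `COc1cc(-c2nnc(SCc3ccc(F)cc3)n2/N=C/c2ccccc2)cc(OC)c1OC` was tested in a functional assay on MCF7 cells (Homo sapiens) for cytotoxicity, read by MTT assay, with a stated time of 48 h; on this read-out lower numbers stand for stronger inhibition and higher numbers for weaker inhibition. In this assay compound 1 reaches only the limit of > 200000 nM, which is the edge of what the assay can report rather than a measured number. Compound 2 `COc1cc(-c2nnc(SCc3ccccc3Cl)n2/N=C/c2ccccc2)cc(OC)c1OC` likewise reaches only the limit, giving > 200000 nM in this assay. For the measured compounds named here, the one measured step, a step that the two limits leave unreadable from compound 1 to compound 2, therefore cannot be sized, since (the limit of > 200000 nM in this assay, at which 2 of the 2 values shown sit). Compound 3 `COc1ccc(/C=N/n2c(SCc3ccc(F)cc3)nnc2-c2cc(OC)c(OC)c(OC)c2)c(OC)c1` is the compound still to be measured. It differs from compound 1 by 2,4-dimethoxyphenyl in place of phenyl on a carbon with a double bond to nitrogen. Going by the values given here, no measured step touches this position, and the only step on record is unreadable, so neither direction nor size of the change in this assay can be drawn from the numbers at hand. With compound 1 sitting at the limit, the value of compound 3 in this assay is expected to stay near that limit, amounting to an expected step that the limit leaves unreadable from compound 1 to compound 3, most likely again reported as a limit rather than a number. Compound 3 is thus estimated at 250000 nM, within a range from 60000 nM to 1000000 nM.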

Compound 3, half-maximal inhibitory concentration: > 200000 nM
Compound 3: only a limit was reported; the forecaster's own chance of this, stated with the estimate: 75%; the middle value lies beyond the limit too.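

Compound 3, like compound 1, is reported only as a limit in this assay, so the change from phenyl to 2,4-dimethoxyphenyl cannot be read as a step of any size: the limit of > 200000 nM in this assay, at which 3 of the 3 values shown sit.

The compounds shown leave open how far each one lies beyond that limit, and whether either change alters cytotoxicity at all.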